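Swapping a sec-butyl for a hydroxyethyl on the imine nitrogen

A few compounds are considered here, and "the series" means these few. Any claim that something is new, unique, unknown or untested is made for them only; others in the source may bear on it.

Compound 1 `C/C(=N\CC(C)C)c1c(O)c2ccccc2oc1=O`: in an assay on isolated protein for inhibition of myosin-2 (Bos taurus), read by spectrophotometry, with a stated time of 24 min (a higher number here means a weaker inhibitor, a lower number a stronger inhibitor), compound 1 gives 34000 nM.
Compound 2 `C/C(=N\Cc1ccccc1)c1c(O)c2ccccc2[nH]c1=O`: in this assay compound 2 gives >= 100000 nM, which is a limit of the assay and not a number.
Compound 3 `CCC(C)/N=C(\C)c1c(O)c2ccccc2[nH]c1=O`: in this assay compound 3 gives >= 100000 nM, again a limit of the assay rather than a number.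

Compound 3 therefore stands at the weak end of what is shown: only a limit is known for it, and compound 2 sits at the same limit. Among the measured compounds shown here, compound 1 has a different core from compound 3 and differs in a second place as well, so no single step links them; its value simply shows a measurable, though weak, inhibitor.

For the measured compounds named here, the one measured step that touches compound 3 is a step that the two limits leave unreadable from compound 2 to compound 3. Its size cannot be read because both of its values sit at the limit of >= 100000 nM in this assay, at which 2 of the 3 values shown sit. So nothing shown tells how changing the group on the double-bonded nitrogen moves potency.

Compound 4 `C/C(=N\CCO)c1c(O)c2ccccc2[nH]c1=O` differs from compound 3 by 2-hydroxyethyl in place of sec-butyl on a double-bonded nitrogen. With no readable step to lean on, the expectation is that compound 4 stays near the limit, and the estimated step of a number no higher from compound 3 to compound 4 (the limit leaves the size open) is taken as none beyond the scatter. Compound 4 is thus expected to give about 100000 nM in this assay, with a range from 30000 nM to 300000 nM, and most likely only a limit is reported.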

Compound 4, half-maximal inhibitory concentration: >= 100000 nM
Compound 4 was reported as a limit; the forecaster's own chance of this, stated with the estimate: 70%; the middle value lies on the limit itself.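

No new step can be read from compound 2 to compound 4 or from compound 3 to compound 4, because all three compounds sit at the same limit: the limit of >= 100000 nM in this assay, at which 3 of the 4 values shown sit. How far benzyl, sec-butyl or 2-hydroxyethyl on the double-bonded nitrogen moves potency in this assay stays open in the compounds shown.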